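Dropping the Hydroxy Group from the Shared Core

This account rests on a few compounds, and the source may have more. Where it says the series, first, only, none or still open, it means among the compounds named here.

Compound 1 `Cc1cc(-c2ccc3ccc(C(=O)c4ccc(F)c(O)c4)nc3c2)ccc1O` gives 80% in an assay for inhibition of 17-beta-hydroxysteroid dehydrogenase type 2 (Homo sapiens), read by HPLC, with a stated time of 10 min, tested at 1 uM; on this read-out higher numbers stand for more inhibition at the one concentration tested (going by the name of the read-out) and lower numbers for less inhibition.
Compound 2 `N#Cc1ccc2ccc(C(=O)c3ccc(F)c(O)c3)nc2c1` gives 56%.
Compound 3 `O=C(c1ccc(F)c(O)c1)c1ccc2cc(O)ccc2n1` gives 71%.

Among these three numbers compound 3 stands second highest. Its gap to compound 1 lies within the usual scatter, so the two cannot be ranked against each other; its gap to compound 2 lies beyond the scatter, so compound 3 clearly inhibits more than compound 2 at this concentration.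

Compound 4 `O=C(c1ccc(F)c(O)c1)c1ccc2ccccc2n1` differs from compound 3 in one place: hydrogen in place of hydroxy on an aromatic carbon. Among the compounds with values here, only one measured step is available for comparison, a number 24 percentage points lower from compound 1 to compound 2 (beyond the scatter), and that step exchanges an entire hydroxy-bearing aryl group for a cyano group, a much larger change than the loss of a single hydroxy. Within the data shown here, no measured pair isolates the removal of a hydroxy from the shared core.

What the three measured compounds do show is that the two carrying a hydroxy on an aromatic ring, compound 1 and compound 3, give the higher numbers, while compound 2 gives the lowest. On that slim basis a modest decrease is expected in this assay for compound 4, smaller than the step from compound 1 to compound 2. Compound 4 is therefore estimated at 60%, within 40% to 78%. The expected step is a number 11 percentage points lower from compound 3 to compound 4 (beyond the scatter).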

Compound 4, a percentage reported as inhibition, at one concentration (the size of the read-out at that concentration, not a potency): 76%
The estimate for compound 4 lay 16 percentage points below the measured number, within the range that was stated.
By their numbers in this assay, from the lowest: compound 2; then compounds 3, 4 and 1 (each within the scatter of the next).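

In this assay, removing the hydroxy from the shared core gives a number 5 percentage points higher from compound 3 to compound 4 (within the scatter), so this aromatic carbon carries no hydroxy that can be shown to matter for inhibition at the one concentration tested. The large aryl group tells a similar story: replacing it gives a number 4 percentage points lower from compound 1 to compound 4 (within the scatter), which means that the 4-hydroxy-3-methylphenyl group cannot be told apart from plain hydrogen on this read-out, and the bare core alone matches the two substituted compounds. Within the data shown here, the nitrile is the exception, since hydrogen in its place gives a number 20 percentage points higher from compound 2 to compound 4 (beyond the scatter), and this makes compound 2 the only compound here that clearly separates from compound 4.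

Still open, from the compounds shown here alone, is how other groups on these aromatic carbons would behave, for example a methoxy, an amine or a carboxylic acid, and whether any of them would shift the number beyond the scatter in either direction. Nothing given here explains why the nitrile stands apart while the hydroxy and the aryl group do not.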